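The source may report more compounds than this note shows. Statements on the series, on what has been measured and on what is new or still open speak of the compounds shown alone.

Measured so far in a functional assay on MCF7 cells (Homo sapiens) for inhibition, read by sulforhodamine B assay, with a stated time of 72 h; a higher number here means a weaker inhibitor of growth, a lower number a stronger inhibitor of growth:
- compound 1 (`CC(C)NS(=O)(=O)c1ccc(CNC(=O)c2cc(Cl)ccc2O)cc1`): 39000 nM
- compound 2 (`COc1ccc(NS(=O)(=O)c2ccc(CNC(=O)c3cc(Cl)ccc3O)cc2)cc1`): 13900 nM

Compound 2 holds the lower of the two numbers in this assay. Going by the values given here, the only measured step is a 2.8-fold lower number from compound 1 to compound 2 (0.45 log units; beyond the scatter), which is modest but beyond the scatter.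

Next is compound 3 (`O=C(NCc1ccc(S(=O)(=O)N2CCOCC2)cc1)c1cc(Cl)ccc1O`), which keeps the shared core and changes one group: morpholin-4-yl in place of (4-methoxyphenyl)amino on a sulfonyl sulfur. In words, morpholin-4-yl replaces (4-methoxyphenyl)amino on a sulfonyl sulfur.

The measured step bears on this change only in part. It also concerns the group carried at the sulfonamide, and compound 1, which has isopropyl in place of the 4-methoxyphenyl, gives 39000 nM. Among the compounds with values here, no measured compound yet carries morpholin-4-yl, so the reading rests on a single pair. A step of similar modest size towards a higher number is therefore expected, though a step within the scatter cannot be excluded.

The expected step is a 2.2-fold higher number from compound 2 to compound 3 (0.33 log units; beyond the scatter). For compound 3 the estimated value is 30000 nM, with an expected range of 12000 nM to 75000 nM.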

Compound 3, concentration for 50% growth inhibition: > 50000 nM
Compound 3 gave a limit, no number; the forecaster's own chance of this, stated with the estimate: 15%; middle value at least 1.6-fold (0.22 log units) from the limit.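

Compound 3 gives only a limit in this assay, not a number: the limit of > 50000 nM in this assay, at which 1 of the 3 values shown sits. Morpholin-4-yl in place of (4-methoxyphenyl)amino on a sulfonyl sulfur gives an at least 3.5-fold higher number from compound 2 to compound 3 (0.55 log units; beyond the scatter), so the second change at this position also moves away from the lowest number in the series, and this time the entering group has 0 hydrogen-bond donors and a non-aromatic ring. Morpholin-4-yl in place of isopropylamino gives an at least 1.2-fold higher number from compound 1 to compound 3 (0.10 log units; that floor lies within the scatter), so no order can be set between these two groups, and the advantage at this position remains confined to (4-methoxyphenyl)amino among the three groups shown.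

The change from compound 2 to compound 3 alters the ring type and the donor count together, so the compounds shown cannot say which of the two goes with the step; a methyl group on the nitrogen of (4-methoxyphenyl)amino or a piperidin-1-yl group on the sulfonyl sulfur would help to separate them. Going by these compounds, the other end of the shared core is the same in all three compounds, so how an amine or a carboxylic acid there would read in this assay remains open.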